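The source may report more compounds than this note shows. Statements on the series, on what has been measured and on what is new or still open speak of the compounds shown alone.

Of the compounds shown here, three built around the same core have been measured in an assay on COS cells for binding affinity to Alpha-1A adrenergic receptor (Homo sapiens); a lower number here means a stronger inhibitor, a higher number a weaker inhibitor. Compound 1 `COc1ccccc1N1CCN(CCCNC(=O)CN2CCCCC2=O)CC1` gives 98 nM in this assay. Compound 2 `CC(C)Oc1ccccc1N1CCN(CCNC(=O)CN2CCCCCC2=O)CC1` gives 18 nM. Compound 3 `CC(C)Oc1cc(F)ccc1N1CCN(CCNC(=O)CN2CCCCC2=O)CC1` gives 83 nM, the second highest of the three numbers; the number of compound 1 lies within the usual scatter of it, while compound 2 sits furthest away, with a lower number that lies beyond the scatter. Compound 2 differs from compound 3 in more than one place, so the two values are only set side by side here and no single change is tied to that gap.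

Compound 4 `O=C(CN1CCCCC1=O)NCCN1CCN(c2ccc(F)cc2OCC(F)(F)F)CC1` has not yet been measured. It differs from compound 3 in one place: 2,2,2-trifluoroethyl in place of isopropyl on an oxygen on an aromatic ring, which reads as isopropoxy to 2,2,2-trifluoroethoxy when the cut is taken one bond further out. For the measured compounds named here, no pair of measured compounds shows this exchange, so there is no reference step to lean on. The expectation is a step from compound 3 to compound 4 of a 1.2-fold higher number from compound 3 to compound 4 (0.08 log units; within the scatter) in this assay, small, in no firm direction, and most likely not beyond the scatter. Compound 4 is therefore expected to give about 100 nM, with a plausible range from 30 nM to 330 nM.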

Compound 4, inhibition constant: 129 nM
Beside the measured number, compound 4's estimate is 1.3-fold (0.11 log units) below it; low and high end bracket the measured number.
By their numbers in this assay, from the lowest: compound 2; then compounds 3, 1 and 4 (each within the scatter of the next).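

For the compounds shown here, replacing isopropyl with 2,2,2-trifluoroethyl on the oxygen on the aromatic ring gives a 1.6-fold higher number from compound 3 to compound 4 (0.19 log units; within the scatter) in this assay and so offers the first reading of a single exchange in this set, as no earlier pair of compounds differed in only one place. At this position, a group of 5 heavy atoms, 3 of them fluorine, can stand in for a group of 3 carbon atoms with no difference in this assay that can be told apart from the usual scatter of repeated measurements. No supporting measurement bears on why the two groups read alike, so this remains a plain observation for this one pair.

Going by these compounds, the exchange has been read only on the core of compound 3, so it remains open whether it would give a similar result on the core of compound 2, which has the lowest number in the set. On these data alone, it also remains open how other groups on this oxygen, such as a cyclopropylmethyl, a benzyl or a longer alkyl chain, would compare with isopropyl and 2,2,2-trifluoroethyl.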